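This account rests on a few compounds, and the source may have more. Where it says the series, first, only, none or still open, it means among the compounds named here.

Measured compounds:
compound 1, `CC(C)c1cc(N)c2cc(NC(=O)/C=C/c3ccc(C(F)(F)F)cc3)ccc2n1`: 2.1 nM
compound 2, `CCCc1cc(N)c2cc(NC(=O)/C=C/c3ccc(I)cc3)ccc2n1`: 2.3 nM
compound 3, `CCCc1cc(NC2CC2)c2cc(NC(=O)/C=C/c3ccc(C(F)(F)F)cc3)ccc2n1`: 40 nM

In an assay on isolated protein for displacement of a labelled ligand from melanin-concentrating hormone receptor 1 (Homo sapiens) (a lower number here means a stronger inhibitor, a higher number a weaker inhibitor), compound 1 and compound 2 give numbers that lie within the usual scatter of each other, so no order between them can be read. Among the measured compounds shown here, compound 3, which carries a cyclopropyl on the amino nitrogen in place of the free amino group, gives a number well beyond the scatter above both; no single-point step links it to either of the other two, so only the two values themselves are compared here.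

Compound 4, `Nc1cc(C2CCC2)nc2ccc(NC(=O)/C=C/c3ccc(C(F)(F)F)cc3)cc12`, has not yet been measured. It keeps the core, the free amino group and the trifluoromethyl-bearing cinnamamide of compound 1 and differs from it in one place: cyclobutyl in place of isopropyl on an aromatic carbon. The change swaps one small saturated carbon group for another of similar size, with no change in donors, acceptors or charge. For the measured compounds named here, no measured pair covers such a swap, so the expectation rests on the closeness of the two groups alone. A step of a 1.4-fold higher number from compound 1 to compound 4 (0.15 log units; within the scatter) is expected in this assay, that is, none beyond the scatter, with a weak lean toward a slightly higher number. Compound 4 is therefore estimated at 3 nM, within a range of 1 nM to 9 nM.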

Compound 4, half-maximal inhibitory concentration: 2 nM
Compound 4: middle estimate off by 1.5-fold (0.18 log units), on the high side; measured number inside the range.
By their numbers in this assay, from the lowest: compounds 4, 1 and 2 (each within the scatter of the next); then compound 3.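

In this assay, among the compounds shown here, cyclobutyl in place of isopropyl on the aromatic carbon next to the ring nitrogen gives a 1.1-fold lower number from compound 1 to compound 4 (0.02 log units; within the scatter) and is the first change that can be read at a single place. At this position, therefore, the open isopropyl and the four-membered carbon ring cannot be told apart in this assay, so closing a ring and adding one carbon do not move the number beyond the scatter. Nothing measured here bears on why the two groups read alike.

From the compounds shown here alone, how a phenyl ring, a hydroxyl group or an amine on this same aromatic carbon would read remains open. The cyclopropyl on the amino nitrogen also has no single-place partner among the compounds shown, so its share in the number of compound 3 at 40 nM cannot be separated.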